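Methyl on two cores: a recorded step and an expected one

The source may report more compounds than this note shows. Statements on the series, on what has been measured and on what is new or still open speak of the compounds shown alone.

The series has two cores. Compound 1 `O=[N+]([O-])c1cccc(Nc2nc3ncccc3n2Cc2ccccc2)c1` and compound 2 `Cc1ccc(Nc2nc3ncccc3n2Cc2ccccc2)cc1[N+](=O)[O-]` share the first; compound 3 `NS(=O)(=O)c1ccc(Nc2nccc(-n3ncc4cccnc43)n2)cc1` carries the second, and the difference between the two cores is not broken down here. In a functional assay on HCT-116 cells (Homo sapiens) for antiproliferative activity, read by MTT assay, with a stated time of 72 h (a lower number here means a stronger inhibitor of growth, a higher number a weaker inhibitor of growth), compound 1 gives 41700 nM, and compound 2 gives 40400 nM; the two sit within the scatter of each other. Compound 3 gives 8040 nM, the lowest number of the three, and both measured steps toward it lie beyond the scatter, so compound 3 counts as the strongest growth inhibitor recorded so far.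

Within the data shown here, the one recorded single change is methyl in place of hydrogen on an aromatic carbon, and it produced a 1.0-fold lower number from compound 1 to compound 2 (0.01 log units; within the scatter). Compound 4 `Cc1nn(-c2ccnc(Nc3ccc(S(N)(=O)=O)cc3)n2)c2ncccc12` is not yet measured and differs from compound 3 by methyl in place of hydrogen on an aromatic carbon. Among the measured compounds shown here, this is the same kind of change as the one from compound 1 to compound 2, but not the same: there the methyl entered on a six-membered aromatic ring of carbon only, ortho to a nitro group and para to a large group; here it enters on a five-membered aromatic ring with 2 nitrogen, part of a fused system of two rings, next to the ring nitrogen and two ring bonds from the ring atom that bears a large group.

For the measured compounds named here, with only one recorded methyl step to rest on, and that one within the scatter, the step from compound 3 to compound 4 is expected to be small, about a 1.1-fold lower number from compound 3 to compound 4 (0.06 log units; within the scatter), because the earlier methyl step gave a 1.0-fold lower number from compound 1 to compound 2 (0.01 log units; within the scatter). Compound 4 is therefore estimated at 7000 nM in this assay, most likely between 3000 nM and 16000 nM.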

Compound 4, concentration for 50% growth inhibition: 8840 nM
Compound 4: middle estimate off by 1.3-fold (0.10 log units), on the low side, and the stated range covers the measured number.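

In this assay, methyl in place of hydrogen on an aromatic carbon gives no step beyond the scatter on the second core, where the step reads a 1.1-fold higher number from compound 3 to compound 4 (0.04 log units; within the scatter). Set beside the earlier step on the first core, the new step does not differ from it: the same change on two cores in this assay, a 1.0-fold lower number (0.01 log units; within the scatter) from compound 1 to compound 2 and a 1.1-fold higher number (0.04 log units; within the scatter) from compound 3 to compound 4, 1.1-fold (0.05 log units) apart, within the scatter of two such steps. This shows that, for these two pairs, the change carries from one core to the other without a step beyond the scatter, but it rests on one pair per core with the methyl at a different kind of place on each, so it gives no general rule for methyl on other ring carbons, on other cores or in other assays.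

Still open, on these data alone, is whether something other than methyl on the carbon of the five-membered aromatic ring, such as an amine, a carboxylic acid or a longer chain, would give a step beyond the scatter from compound 3. Also open is how far the two cores themselves, rather than the groups they carry, account for the difference in their numbers, as no pair shown crosses from one core to the other with a single change.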